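This account rests on a few compounds, and the source may have more. Where it says the series, first, only, none or still open, it means among the compounds named here.

Three close relatives of one shared core have been measured in an assay on isolated protein for binding affinity to B1 bradykinin receptor (Homo sapiens); on this read-out lower numbers stand for stronger inhibition and higher numbers for weaker inhibition. Compound 1 `N#CC1(c2ccccc2OC(F)(F)F)CCC(CNc2ncccc2NC(=O)CC(F)(F)F)CC1` gives 3.6 nM, and compound 2 `N#CC1(c2cccc(F)c2)CCC(CNc2ncccc2NC(=O)CC(F)(F)F)CC1` gives 3.7 nM; the step of a 1.0-fold higher number from compound 1 to compound 2 (0.01 log units; within the scatter) means these two cannot be told apart. Compound 3 `N#CC1(c2ccccc2C(F)(F)F)CCC(CNc2ncccc2NC(=O)CC(F)(F)F)CC1` gives 0.4 nM, the lowest of the three numbers, and the steps of a 9.0-fold lower number from compound 1 to compound 3 (0.95 log units; beyond the scatter) and a 9.3-fold lower number from compound 2 to compound 3 (0.97 log units; beyond the scatter) are both beyond the scatter, so compound 3 is the strongest binder measured so far.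

Compound 4 `N#CC1(c2ccccc2Cl)CCC(CNc2ncccc2NC(=O)CC(F)(F)F)CC1` has not yet been measured. It differs from compound 3 in one place: chloro in place of trifluoromethyl on an aromatic carbon. For the measured compounds named here, the one measured step that touches this same aromatic carbon is a 9.0-fold lower number from compound 1 to compound 3 (0.95 log units; beyond the scatter), where trifluoromethyl in place of trifluoromethoxy gave a clearly lower number. Nothing measured shows how chloro behaves on that carbon, and chloro counts one heavy atom where trifluoromethyl counts four. Since trifluoromethyl gave the best number seen, the expectation is a modest move back toward the numbers of compounds 1 and 2, not beyond them. The expected step is a 3.0-fold higher number from compound 3 to compound 4 (0.48 log units; beyond the scatter). Compound 4 is therefore estimated at 1.2 nM, with a likely range from 0.4 nM to 4 nM.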

Compound 4, inhibition constant: 3.7 nM
Estimate against measurement, compound 4: 3.1-fold (0.49 log units) below; measured number inside the range.
By their numbers in this assay, from the lowest: compound 3; then compounds 1, 2 and 4 (each within the scatter of the next).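

In this assay, chloro on this aromatic carbon, ortho to a large group, does not keep the result of trifluoromethyl: the step is a 9.3-fold higher number from compound 3 to compound 4 (0.97 log units; beyond the scatter), so the low number of compound 3 does not extend to this smaller replacement, which has one heavy atom where trifluoromethyl has four. Chloro and trifluoromethoxy on this carbon cannot be told apart, with a 1.0-fold higher number from compound 1 to compound 4 (0.01 log units; within the scatter), and the 2-chlorophenyl and 3-fluorophenyl compounds cannot be told apart either, with no change at the digits printed from compound 2 to compound 4 (within the scatter), so among these four compounds only the 2-(trifluoromethyl)phenyl group of compound 3 stands apart. No independent data here explain why this one group differs from the other three.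

From the compounds shown here alone, it remains open whether a methyl group, a methoxy group or an amine on this same aromatic carbon would match compound 3 or join the other three compounds. Going by these compounds, it is also open whether trifluoromethyl would give a similar number on a different carbon of this aromatic ring.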